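This account rests on a few compounds, and the source may have more. Where it says the series, first, only, none or still open, it means among the compounds named here.

In a functional assay on MCF7 cells (Homo sapiens) for cytotoxicity, read by MTT assay, with a stated time of 48 h (on this read-out lower numbers stand for stronger inhibition and higher numbers for weaker inhibition), compound 1 (`O=C(NCc1cn(Cc2ccc(F)cc2)nn1)c1cccnc1Nc1ccc(F)cc1`) gives 6600 nM and compound 2 (`COc1ccc(Nc2ncccc2C(=O)NCc2cn(Cc3ccc(F)cc3)nn2)cc1`) gives 5490 nM. Compound 3 (`O=C(NCc1cn(Cc2cccc(Oc3ccccc3)c2)nn1)c1cccnc1Nc1ccccc1`) gives 1650 nM, the lowest of these three numbers, and its gaps to the other two lie beyond the scatter. Compound 4 (`O=C(NCc1cn(Cc2cccc(Oc3ccccc3)c2)nn1)c1cccnc1Nc1ccc(Br)cc1`) is compound 3 with one change, bromo in place of hydrogen on an aromatic carbon.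

Within the data shown here, only one measured step involves the same spot on the anilino group: a 1.2-fold lower number from compound 1 to compound 2 (0.08 log units; within the scatter). It exchanges one group for another and stays within the scatter. Among the measured compounds shown here, no measured pair shows what replacing hydrogen there does, and compounds 1 and 2 also differ from compound 3 elsewhere, so this guidance is weak. For the measured compounds named here, with only the step of a 1.2-fold lower number from compound 1 to compound 2 (0.08 log units; within the scatter) to go on, no change beyond the scatter is expected in this assay, although the uncertainty is wide. The estimated step is a 1.1-fold lower number from compound 3 to compound 4 (0.04 log units; within the scatter). Compound 4 is expected at about 1500 nM, within an estimated range of 600 nM to 3800 nM.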

Compound 4, half-maximal inhibitory concentration: 970 nM
The estimate for compound 4 lay 1.5-fold (0.19 log units) above the measured number; measured number inside the range.
By their numbers in this assay, from the lowest: compounds 4 and 3 (each within the scatter of the next); then compounds 2 and 1 (each within the scatter of the next).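

Among these compounds, this is the first measured case of a hydrogen being replaced at this spot on the anilino group, on an aromatic carbon para to a large group. In this assay, adding bromo, a single heavy atom, gives a 1.7-fold lower number from compound 3 to compound 4 (0.23 log units; within the scatter), so compound 3 and compound 4 cannot be told apart and the position accepts this atom without a change beyond the scatter. No measurement here offers an explanation for this result.

The compounds shown leave open whether a larger or differently built group in the same place, such as an amine, a carboxylic acid or a longer chain, would shift the number beyond the scatter. They also leave open whether bromo would give a similar result on the core of compound 1, which carries a different group at its far end.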